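Thienylmethyl Amine Replaces the Difluoroanilino Group

The compounds below may be only part of what the source reports. "The series", "measured", "known", "first", "only" and "open" are said of these compounds alone.

Measured compounds:
compound 1 `C=CC(=O)Nc1cc(Nc2ncc(Cl)c(Nc3cccc(C(F)(F)F)c3)n2)c(OC)cc1N1CCN(C)CC1` — 770 nM
compound 2 `C=CC(=O)Nc1cc(Nc2ncc(Cl)c(Nc3c(F)cccc3F)n2)c(OC)cc1N1CCN(C)CC1` — 2900 nM

In a functional assay on NCI-H3122 cells (Homo sapiens) for inhibition, read by CellTiter-Glo, with a stated time of 72 h (on this read-out lower numbers stand for stronger inhibition of growth and higher numbers for weaker inhibition of growth), compound 1 gives 770 nM, while compound 2 gives 2900 nM. Going by the values given here, the only step between the two is a 3.8-fold higher number from compound 1 to compound 2 (0.58 log units; beyond the scatter). Among the compounds with values here, compound 2 therefore stands at the higher of the two numbers, and its only neighbour, compound 1, sits a modest step below it.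

Compound 3 `C=CC(=O)Nc1cc(Nc2ncc(Cl)c(NCc3cccs3)n2)c(OC)cc1N1CCN(C)CC1` has not yet been measured in this assay. It differs from compound 2 by (thiophen-2-yl)methyl in place of 2,6-difluorophenyl on a nitrogen on an aromatic ring. Within the data shown here, no measured step bears directly on this change: the one known step exchanges one six-membered aromatic ring of carbon only for another, both sitting straight on the nitrogen, whereas here a five-membered aromatic ring with one hetero atom arrives as a (thiophen-2-yl)methyl group. With so little to go on, and with the known step being only modest, compound 3 is expected to stay close to compound 2, with broad uncertainty either way. For compound 3 the expected step is a 1.2-fold higher number from compound 2 to compound 3 (0.08 log units; within the scatter). Compound 3 is thus estimated at 3500 nM, within a range from 900 nM to 14000 nM.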

Compound 3, concentration for 50% growth inhibition: 270 nM
Estimate against measurement, compound 3: 13-fold (1.11 log units) above; the measured number lies below the stated range.
By their numbers in this assay, from the lowest: compound 3; then compound 1; then compound 2.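

In this assay, this position proves far more responsive than the earlier pair suggested: the change to (thiophen-2-yl)methyl gives a large step (an 11-fold lower number from compound 2 to compound 3 (1.03 log units; beyond the scatter)), whereas exchanging one phenyl group for another gave only a modest one (a 3.8-fold higher number from compound 1 to compound 2 (0.58 log units; beyond the scatter)). The new group also outdoes the 3-(trifluoromethyl)phenyl group (a 2.9-fold lower number from compound 1 to compound 3 (0.46 log units; beyond the scatter)), so compound 3 has the lowest number of the three, with both of its steps beyond the scatter. The position on the nitrogen therefore accepts more than a six-membered aromatic ring of carbon only sitting directly on that nitrogen, and a five-membered aromatic ring with a sulfur atom, attached through a methyl link, is the best of the groups shown here.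

The step changes the ring and adds the link at once, so the compounds shown cannot say which of the two matters, a question that a benzyl group, a thiophen-2-yl group set directly on the nitrogen, or a longer chain carrying the thiophene would bear on. Nothing in hand explains why the number falls so far with this change.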